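The source may report more compounds than this note shows. Statements on the series, on what has been measured and on what is new or still open speak of the compounds shown alone.

Of the compounds shown here, three sharing one core have been tested in a functional assay on HT-22 cells (Mus musculus), read by MTT assay, with a stated time of 24 h; on this read-out lower numbers stand for an effect already at smaller amounts and higher numbers for an effect only at larger amounts of compound. For the measured compounds named here, compound 2 `COc1cc(-c2ccc(N(C)C)cc2)nc2ccccc12` gives 60 nM, the only number available, so it has no measured neighbour to be ranked against. Compound 1 `COc1cc(-c2ccc(O)cc2)nc2ccccc12` is reported as "not active" (no number reported), with no number attached. Compound 3 `COc1cc(-c2ccc(N3CCCC3)cc2)nc2ccccc12` is likewise reported as "not active" (no number reported).

The next compound to be measured is compound 4 `CC(C)Oc1cc(-c2ccc(N(C)C)cc2)nc2ccccc12`, which keeps everything in compound 2 except one group: isopropyl in place of methyl on an oxygen on an aromatic ring. In words, this is isopropyl in place of methyl on an oxygen on an aromatic ring, or methoxy to isopropoxy. Going by the values given here, no measured pair shows this change, so the data give no direct guide to its size.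

The only hint is indirect. Compound 2 reads 60 nM, while compound 3, which differs from it in another group, reads "not active" (no number reported), so a single change in this small set can end without a number. On that basis, a moderate move toward a higher number in this assay, beyond the usual scatter, is expected, and it is estimated as a 2.5-fold higher number from compound 2 to compound 4 (0.40 log units; beyond the scatter). A result with no number at all also remains possible. For compound 4 the expected value is 150 nM, within an estimated range of 25 nM to 1000 nM.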

Compound 4, half-maximal effective concentration: 50 nM
The estimate for compound 4 lay 3.0-fold (0.48 log units) above the measured number; the range from low to high includes it.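

In this assay, putting isopropyl in place of methyl on an oxygen on an aromatic ring gives a 1.2-fold lower number from compound 2 to compound 4 (0.08 log units; within the scatter), so compound 2 and compound 4 cannot be told apart on this read-out, even though the group grows from 1 heavy atom to 3. For the compounds shown here, this is the first measured step in the set, and it shows that a change at this oxygen can keep a measurable effect, whereas with a difference from compound 2 at another place, compound 3 is reported as "not active" (no number reported). No measurement shown here offers an explanation for this result.

One pair cannot show how much further this oxygen can be changed: a longer butyl chain, a chain ending in an amine or a chain ending in a carboxylic acid could each behave differently from isopropyl. As far as these compounds go, it also remains open whether methoxy to isopropoxy would have a similar outcome in the setting of compound 1 or compound 3, since neither offers a number to start from.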